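Ethyl for 4-fluorophenyl: working notes on compound 3

The compounds below may be only part of what the source reports. "The series", "measured", "known", "first", "only" and "open" are said of these compounds alone.

Measured in a functional assay on J774.A1 cells (Mus musculus) for inhibition, read by Griess assay, with stated times of 1 h and 24 h; on this read-out higher numbers stand for weaker inhibition and lower numbers for stronger inhibition:
- compound 1 `O=C1CC(c2ccccc2OCc2ccc(F)cc2)Oc2ccccc21`: 25500 nM
- compound 2 `CC(C)CCOc1ccccc1C1CC(=O)c2ccccc2O1`: 42600 nM

Only these two numbers are available, and they lie within the scatter of each other, so compound 1 cannot be ranked against compound 2. Neither value can be called the better one.

The next structure is compound 3 `CCCOc1ccccc1C1CC(=O)c2ccccc2O1`. The change is ethyl in place of 4-fluorophenyl on a saturated chain carbon bound to an oxygen on an aromatic ring.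

Among the measured compounds shown here, one measured step bears on this change: a 1.7-fold higher number from compound 1 to compound 2 (0.22 log units; within the scatter). It puts isobutyl in place of 4-fluorophenyl at the same kind of carbon and stays within the scatter. For the measured compounds named here, no ethyl example has been measured, so this single step is the whole basis for the expectation. No step beyond the scatter is expected in this assay, and no direction can be assigned with confidence.

The expected step is a 1.3-fold higher number from compound 1 to compound 3 (0.11 log units; within the scatter). For compound 3 the estimated value is 33000 nM, with an expected range of 15000 nM to 75000 nM.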

Compound 3, half-maximal inhibitory concentration: 44600 nM
Estimate against measurement, compound 3: 1.4-fold (0.13 log units) below; the measured number falls inside the stated range.
By their numbers in this assay, from the lowest: compounds 1, 2 and 3 (each within the scatter of the next).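

In this assay, the ethyl for 4-fluorophenyl change, which cut one bond further out reads 4-fluorobenzyl to propyl, takes the aromatic ring out of this place and leaves 2 heavy atoms where 7 stood, yet it gives only a 1.7-fold higher number from compound 1 to compound 3 (0.24 log units; within the scatter). The change of methyl for isopropyl on a saturated chain carbon, two bonds along the chain from an oxygen on an aromatic ring, gives a 1.0-fold higher number from compound 2 to compound 3 (0.02 log units; within the scatter), so compound 2 and compound 3 cannot be told apart, and across these three compounds neither change separates one from another in this read-out; no supporting data are available to account for this.

Still open is whether any group at this place can move the number beyond the scatter, for example an amine, a carboxylic acid or a chain longer than the ones shown here. All three compounds also share one core and carry their substituent in one place, so the compounds shown say nothing about changes to the core of compound 1 or about a methoxy group or a hydroxyl in place of these chains.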